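A few compounds are considered here, and "the series" means these few. Any claim that something is new, unique, unknown or untested is made for them only; others in the source may bear on it.

Of the compounds shown here, three have numbers so far. Compound 1 `CC1=CC[C@H]2[C@@H]1CC=C(C)[C@@H](CC[C@H]1[C@]3(C)CC[C@H](O)C(C)(C)O[C@H]3CC[C@@]1(C)O)C2(C)C` gives in a functional assay on MCF7 cells (Homo sapiens) for antiproliferative activity, read by MTT assay, with a stated time of 72 h (a higher number here means a weaker inhibitor, a lower number a stronger inhibitor), only a limit, > 50000 nM. Compound 2 `C=C(C)C(CC[C@@]1(C)C(CC[C@H]2[C@]3(C)CC[C@H](O)C(C)(C)O[C@H]3CC[C@@]2(C)O)=C(C)CC[C@H]1O)OO` gives 31200 nM. Compound 3 `CC1=C(CC[C@H]2[C@]3(C)CC[C@H](O)C(C)(C)O[C@H]3CC[C@@]2(C)O)[C@](C)(C/C=C/C(C)(C)OO)[C@H](O)CC1` gives 27400 nM.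

Among the two numbers, compound 3 stands lowest, with compound 2 nearest: the step of a 1.1-fold lower number from compound 2 to compound 3 (0.06 log units; within the scatter) lies within the scatter. For the measured compounds named here, the value of compound 1 is a limit of the assay (the limit of > 50000 nM in this assay, at which 1 of the 3 values shown sits), not a number, and gives no step to compare.

Compound 4 `CC(C)=CCC[C@@]1(C)C(CC[C@H]2[C@]3(C)CC[C@H](O)C(C)(C)O[C@H]3CC[C@@]2(C)O)=C(C)CC[C@H]1O` is the next in line. Compared with compound 3 it carries the change (a group of 5 heavy atoms (5 carbon; no ring) in place of a group of 7 heavy atoms (5 carbon, 2 oxygen; no ring), on a saturated chain carbon bound to a saturated ring carbon). Going by the values given here, only one measured step sits at the same place, the step from compound 2 to compound 3, which swapped one group of 7 heavy atoms (5 carbon, 2 oxygen; no ring) for another of the same count and moved the number within the scatter. Among the compounds with values here, no measured step removes the two oxygens from that position, so the present change has no direct precedent in the data.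

On that basis compound 4 is expected to give a step of a 1.5-fold higher number from compound 3 to compound 4 (0.16 log units; within the scatter), a number close to that of compound 3 or somewhat higher. The estimate for compound 4 is 40000 nM, within 18000 nM to 90000 nM.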

Compound 4, half-maximal inhibitory concentration: > 50000 nM
Compound 4: only a limit was reported (the forecaster's own chance of this, stated with the estimate: 40%); middle value at least 1.2-fold (0.09 log units) from the limit.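

For the compounds shown here, this step is the first to take the two oxygens out of the group at this position, since the step between compound 2 and compound 3 only exchanged one oxygen-bearing group for another. With 3-methylbut-2-en-1-yl in their place, compound 4 gives in this assay only a limit, > 50000 nM, so it falls with compound 1 at the edge of what the assay reports: the limit of > 50000 nM in this assay, at which 2 of the 4 values shown sit. The two steps, an at least 1.8-fold higher number from compound 3 to compound 4 (0.26 log units; that floor lies within the scatter) and an at least 1.6-fold higher number from compound 2 to compound 4 (0.20 log units; that floor lies within the scatter), are both floors within the scatter, so the result suggests that the oxygen-bearing groups go with a measurable number here but does not by itself establish a real loss.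

From the compounds shown here alone, how far compound 4 lies past the limit stays unknown, so the true size of both steps remains open, as does whether the oxygens or some other feature of the group matter. Going by these compounds, it is also open whether an amine or a carboxylic acid on this chain would give a number like those of compound 2 and compound 3.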